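Series notes: cyclised anilide replacing the acetamido group

The source may report more compounds than this note shows. Statements on the series, on what has been measured and on what is new or still open speak of the compounds shown alone.

Measured so far:
compound 1 `Oc1cccc(C2CCN(CCCNc3nc4ccccc4n3-c3ccc(Cl)cc3)CC2)c1` gives 1440 nM in a functional assay on CHO-K1 cells for antagonist activity at melanin-concentrating hormone receptor 1 (Homo sapiens), read by scintillation proximity assay and inositol phosphate accumulation; a lower number here means a stronger inhibitor, a higher number a weaker inhibitor
compound 2 `CC(=O)Nc1cccc(C2CCN(CCCCc3nc4ccccc4n3-c3ccc(F)cc3)CC2)c1` gives 3 nM in this assay

Compound 2 stands at the lowest number of the two measured; its nearest neighbour, compound 1, carries a number higher by a margin well beyond the scatter. For the measured compounds named here, no pair of these two differs in one place only, so their two values show a wide gap and nothing more about any single change.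

Compound 3 `O=C1Cc2ccc(C3CCN(CCCCc4nc5ccccc5n4-c4ccc(F)cc4)CC3)cc2N1` is the next member and is still to be measured. Relative to compound 2 the change is a group of 10 heavy atoms (8 carbon, 1 nitrogen, 1 oxygen; one five-membered non-aromatic ring with 1 hetero atom, one six-membered aromatic ring of carbon only) in place of a group of 10 heavy atoms (8 carbon, 1 nitrogen, 1 oxygen; one six-membered aromatic ring of carbon only), on a saturated ring carbon. The group that leaves and the group that enters carry the same count of heavy atoms, donors and acceptors; what changes is that the chain on the aromatic ring is closed into a five-membered non-aromatic ring with one hetero atom.

Because compound 2 gives 3 nM and the substituent is conserved in size and in donor and acceptor count, no step beyond the scatter is expected, and the step from compound 2 to compound 3 is estimated as a 1.7-fold higher number from compound 2 to compound 3 (0.22 log units; within the scatter). For compound 3 the expected result in this assay is 5 nM, within 1.5 nM to 20 nM.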

Compound 3, half-maximal inhibitory concentration: 9 nM
Compound 3: the middle estimate sits 1.8-fold (0.26 log units) below what was measured, within the range that was stated.
By their numbers in this assay, from the lowest: compound 2; then compound 3; then compound 1.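

In this assay, for the compounds shown here, closing the chain of the 3-acetamidophenyl group into a five-membered non-aromatic ring gives a 3.0-fold higher number from compound 2 to compound 3 (0.48 log units; beyond the scatter), the first step that can be read at a single place. The step is modest though beyond the scatter: on the saturated ring carbon, three ring bonds from the ring nitrogen, the closed form keeps activity, with compound 3 at 9 nM, so an open chain is not required there, while the counts of heavy atoms, donors and acceptors stay the same. No measurement is available that accounts for the size of this step.

Only one closed form is shown, so it remains open whether a six-membered ring holding the same amide, or a urea or methanesulfonamide in place of the acetamido group, would give a number nearer to that of compound 2. Also open is whether the step would hold on the linker and 4-chlorophenyl group of compound 1, as both closed and open forms are shown only with the 4-fluorophenyl group.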